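Quinazoline series: a second methoxy group on the aniline ring

The compounds below may be only part of what the source reports. "The series", "measured", "known", "first", "only" and "open" are said of these compounds alone.

Of the compounds shown here, three sharing one core have been tested in a functional assay on PC-3 cells (Homo sapiens) for cytotoxicity, read by MTT assay, with a stated time of 72 h; on this read-out higher numbers stand for weaker inhibition and lower numbers for stronger inhibition. Compound 1 `FC(F)(F)c1ccc(CSc2nc(N3CCCCC3)c3ccccc3n2)cc1` gives 25500 nM. Compound 2 `FC(F)(F)c1ccc(CSc2nc(Nc3ccccc3Cl)c3ccccc3n2)cc1` gives 20400 nM in this assay. Compound 3 `COc1ccc(Nc2nc(SCc3ccc(C(F)(F)F)cc3)nc3ccccc23)cc1` gives 16700 nM in this assay. Compound 2 stands second highest of the three numbers, yet all three sit within the usual scatter of one another: the change from compound 1 to compound 2 was a 1.3-fold lower number from compound 1 to compound 2 (0.10 log units; within the scatter), from compound 1 to compound 3 it was a 1.5-fold lower number from compound 1 to compound 3 (0.18 log units; within the scatter), and from compound 2 to compound 3 it was a 1.2-fold lower number from compound 2 to compound 3 (0.09 log units; within the scatter). So far, no replacement at this position has moved the number beyond the noise.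

Compound 4 `COc1ccc(Nc2nc(SCc3ccc(C(F)(F)F)cc3)nc3ccccc23)cc1OC` has not yet been measured. Its difference from compound 2 is 3,4-dimethoxyphenyl in place of 2-chlorophenyl on a nitrogen on an aromatic ring. The step that bears most directly on it is the one in which 4-methoxyphenyl replaced 2-chlorophenyl on the same nitrogen, a change of a 1.2-fold lower number from compound 2 to compound 3 (0.09 log units; within the scatter). Going by the values given here, the additional methoxy group in compound 4 has no precedent among the measured compounds. The expectation is therefore a step of a 1.3-fold lower number from compound 2 to compound 4 (0.11 log units; within the scatter) in this assay, not beyond the scatter. Compound 4 is estimated at 16000 nM, with a range from 6000 nM to 45000 nM.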

Compound 4, half-maximal inhibitory concentration: 14100 nM
Estimate against measurement, compound 4: 1.1-fold (0.05 log units) above; measured number inside the range.
By their numbers in this assay, from the lowest: compounds 4, 3, 2 and 1 (each within the scatter of the next).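

The added methoxy group, methoxy in place of hydrogen on an aromatic carbon, is the smallest change yet at this position, and in this assay it gives a 1.2-fold lower number from compound 3 to compound 4 (0.07 log units; within the scatter) and so does not separate the two compounds. The larger replacements also stay inside the scatter, with 3,4-dimethoxyphenyl in place of 2-chlorophenyl on the nitrogen giving a 1.4-fold lower number from compound 2 to compound 4 (0.16 log units; within the scatter) and (3,4-dimethoxyphenyl)amino in place of piperidin-1-yl giving a 1.8-fold lower number from compound 1 to compound 4 (0.26 log units; within the scatter) and thus, across all four compounds, neither an added methoxy group nor a full exchange of the group has yet moved the number beyond the noise. No measurement at hand offers a reason for this flat picture.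

Still open, going by these compounds, is whether a quite different group on the phenyl ring, such as an amine or a carboxylic acid, or a longer chain in place of the methoxy group, would shift the number beyond the scatter. Also open, on these data alone, is whether a change away from this position, such as a nitrile in place of trifluoromethyl, would matter more than any exchange seen here.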